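The source may hold more compounds than are shown below. What is called first, only, known or untested is meant among the compounds shown, and "the series" means these compounds.

Three compounds share one core and differ only in the group carried on an aromatic nitrogen of the five-membered ring with three nitrogens. Compound 1 `CCOC(=O)C1=Cc2ccccc2OC1(OCc1cn(-c2ccc(F)cc2)nn1)C(F)(F)F` carries a 4-fluorophenyl group there, and in a functional assay on A549 cells (Homo sapiens) for inhibition, read by MTT assay, with a stated time of 24 h (on this read-out higher numbers stand for weaker inhibition and lower numbers for stronger inhibition), compound 1 gives 7300 nM. Compound 2 `CCOC(=O)C1=Cc2ccccc2OC1(OCc1cn(CC(=O)Nc2ccc(C)cc2)nn1)C(F)(F)F` carries a ((4-methylphenyl)carbamoyl)methyl group, and compound 2 gives 54300 nM. Compound 3 `CCOC(=O)C1=Cc2ccccc2OC1(OCc1cn(-c2ccc(F)c(Cl)c2)nn1)C(F)(F)F` carries a 3-chloro-4-fluorophenyl group, and compound 3 gives 26300 nM, the second highest of the three numbers, with compound 2 nearest and compound 1 furthest.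

Compound 4 `CCOC(=O)C1=Cc2ccccc2OC1(OCc1cn(-c2cccc(C(F)(F)F)c2)nn1)C(F)(F)F` is the next step: 3-(trifluoromethyl)phenyl in place of 3-chloro-4-fluorophenyl on an aromatic nitrogen. Within the data shown here, two measured steps bear on it, both altering the same aryl group on that nitrogen. The step of a 3.6-fold higher number from compound 1 to compound 3 (0.56 log units; beyond the scatter) shows that a single added chloro moved the number beyond the scatter, and the step of a 2.1-fold lower number from compound 2 to compound 3 (0.31 log units; beyond the scatter) shows a smaller shift in the other direction. Swapping one substituted phenyl for another is therefore expected to produce a modest step in this assay, and since compound 3 stands far from the strongest number, compound 4 is estimated to land somewhat lower, as a 1.8-fold lower number from compound 3 to compound 4 (0.24 log units; within the scatter). Compound 4 is expected to give about 15000 nM, ranging from 5000 nM to 45000 nM.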

Compound 4, half-maximal inhibitory concentration: > 150000 nM
Compound 4 gave a limit, no number (the forecaster's own chance of this, stated with the estimate: 5%); middle value at least 10-fold (1.00 log units) away from the limit.
By their numbers in this assay, from the lowest: compound 1; then compound 3; then compound 2. At a limit, above all of these: compound 4.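

In this assay, compound 4 gives only a limit of the assay, not a number: the limit of > 150000 nM in this assay, at which 1 of the 4 values shown sits. Swapping one substituted phenyl group for another on the aromatic nitrogen can therefore produce a far bigger change than the earlier compounds suggested, with an at least 20-fold higher number from compound 1 to compound 4 (1.31 log units; beyond the scatter) as the only large step in the set, alongside an at least 5.7-fold higher number from compound 3 to compound 4 (0.75 log units; beyond the scatter) and an at least 2.7-fold higher number from compound 2 to compound 4 (0.44 log units; beyond the scatter). Having a phenyl group directly on that nitrogen also does not by itself keep the number low, since 3-(trifluoromethyl)phenyl ends up above even the ((4-methylphenyl)carbamoyl)methyl group, which has a chain between the nitrogen and its ring.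

Going by these compounds, compound 4 differs from compound 3 in more than one substituent on the phenyl ring, so it remains open whether the added trifluoromethyl group or the lost chloro and fluoro groups account for the change, and the limit leaves the true size of the step unknown. Also open, on these data alone, is what a plain phenyl group, or a phenyl group carrying a methoxy group or an amine, would give on the same nitrogen.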